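The source may report more compounds than this note shows. Statements on the series, on what has been measured and on what is new or still open speak of the compounds shown alone.

Compound 1 `CC[C@@H]1C[C@H](CC)CN(CCCNC(=O)C2CCN(Cc3nc(-c4ccccc4C)oc3C)CC2)C1` gives 3470 nM.
Compound 2 `Cc1oc(-c2ccccc2Cl)nc1CN1CCC(C(=O)NCCCN2C[C@H](C)C[C@H](C)C2)CC1` gives 16500 nM.
Compound 3 `Cc1ccccc1-c1nc(CN2CCC(C(=O)N3CCN(CCN(C)C)CC3)CC2)c(C)o1` gives 27200 nM.

These three values come from an ADME assay on Huh7.5.1 cells (Homo sapiens) for cytotoxicity, read by ATP content, with a stated time of 48 h; a lower number here means that less compound is tolerated, a higher number that more compound is tolerated. Compound 2 stands second highest of the three numbers; its nearest neighbour is compound 3, whose value lies within the scatter of repeated measurements, while compound 1 lies furthest away, with a clearly lower number beyond the scatter. Compound 4 `COc1cccc(C)c1-c1nc(CN2CCC(C(=O)NCCCN3C[C@H](C)C[C@H](C)C3)CC2)c(C)o1` has not yet been measured. It differs from compound 2 in one place: 2-methoxy-6-methylphenyl in place of 2-chlorophenyl on an aromatic carbon. Among the measured compounds shown here, no pair of measured compounds differing in only one place is available to guide the size of this step in this assay, so no change beyond the scatter is expected in either direction. The expected step from compound 2 to compound 4 is a 1.1-fold lower number from compound 2 to compound 4 (0.04 log units; within the scatter), and compound 4 is estimated at 15000 nM, with a likely range from 5000 nM to 40000 nM.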

Compound 4, half-maximal cytotoxic concentration: 16700 nM
The estimate for compound 4 lay 1.1-fold (0.05 log units) below the measured number; measured number inside the range.
By their numbers in this assay, from the lowest: compound 1; then compounds 2, 4 and 3 (each within the scatter of the next).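

Read in this assay, putting 2-methoxy-6-methylphenyl in place of 2-chlorophenyl gives a 1.0-fold higher number from compound 2 to compound 4 (0.01 log units; within the scatter) and provides the first comparison here of compounds differing in one place. This position on the five-membered ring therefore takes a group with more heavy atoms, including a hydrogen-bond acceptor and no chlorine, with no change beyond the scatter. Nothing measured here offers an explanation for this result. Still open, on these data alone, is whether an amine or a carboxylic acid on this phenyl ring would shift the number beyond the scatter.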